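The source may report more compounds than this note shows. Statements on the series, on what has been measured and on what is new or still open speak of the compounds shown alone.

Working notes on the series. Compounds 1 to 3 share one core and differ only in the group on a saturated chain carbon bound to an aromatic carbon. Compound 1 `OC[C@H]1O[C@@H](n2cnc3c(Cn4ccc5ccccc54)ncnc32)[C@H](O)[C@@H]1O` gives 9100 nM in a functional assay on HL-60 cells (Homo sapiens) for inhibition, read by XTT assay, with a stated time of 72 h; a higher number here means a weaker inhibitor, a lower number a stronger inhibitor. Compound 2 `OC[C@H]1O[C@@H](n2cnc3c(CSCc4ccccc4)ncnc32)[C@H](O)[C@@H]1O` gives 19200 nM in this assay; the step of a 2.1-fold higher number from compound 1 to compound 2 (0.32 log units; beyond the scatter) follows benzylsulfanyl in place of 1H-indol-1-yl. Compound 3 `CN(Cc1ccccc1)Cc1ncnc2c1ncn2[C@@H]1O[C@H](CO)[C@@H](O)[C@H]1O` gives 2400 nM in this assay, the lowest number of the three; the step of a 3.8-fold lower number from compound 1 to compound 3 (0.58 log units; beyond the scatter) follows benzyl(methyl)amino in place of 1H-indol-1-yl, and the step of an 8.0-fold lower number from compound 2 to compound 3 (0.90 log units; beyond the scatter) follows benzyl(methyl)amino in place of benzylsulfanyl. Compound 4 `COCc1ncnc2c1ncn2[C@@H]1O[C@H](CO)[C@@H](O)[C@H]1O` is not yet measured. It differs from compound 3 as follows: methoxy in place of benzyl(methyl)amino on a saturated chain carbon bound to an aromatic carbon.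

Among the compounds with values here, all three measured steps swap the link between the chain carbon and a benzyl or indolyl group while keeping an aromatic ring on that chain; none removes the ring, so no measured step covers the change to compound 4 directly. With the ring gone and only methoxy left, compound 4 is expected to show a higher number than compound 3 by a step of an 8.3-fold higher number from compound 3 to compound 4 (0.92 log units; beyond the scatter), beyond the scatter, with the size uncertain. Compound 4 is therefore estimated at 20000 nM in this assay, with a range from 5000 nM to 80000 nM.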

Compound 4, half-maximal inhibitory concentration: 1680 nM
The estimate for compound 4 lay 12-fold (1.08 log units) above the measured number, and the stated range ends above it.
By their numbers in this assay, from the lowest: compounds 4 and 3 (each within the scatter of the next); then compound 1; then compound 2.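

In this assay, an aromatic ring on the chain is not required at this position: methoxy, with no ring and 2 heavy atoms, replaces benzyl(methyl)amino, with its six-membered aromatic ring and 9 heavy atoms, and gives a 1.4-fold lower number from compound 3 to compound 4 (0.15 log units; within the scatter). Methoxy also compares favourably with the two other ring-bearing groups, giving an 11-fold lower number from compound 2 to compound 4 (1.06 log units; beyond the scatter) and a 5.4-fold lower number from compound 1 to compound 4 (0.73 log units; beyond the scatter), so among these four compounds benzyl(methyl)amino is the only ring-bearing group that methoxy does not clearly outdo. No measurement bearing on the reason for this result is available.

The compounds shown leave open whether the oxygen of methoxy matters at all, since a hydroxyl, a plain hydrogen or a dimethylamino group on the same chain carbon would separate the linking atom from the group it carries. They also leave open how far the chain can grow without a ring, as an ethoxy or a longer alkoxy chain would show, and whether the level shared by compound 3 and compound 4 holds outside this one cell read-out.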